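Replacing the 2-formylthiophen-3-yl group of compound 2

The source may report more compounds than this note shows. Statements on the series, on what has been measured and on what is new or still open speak of the compounds shown alone.

Of the compounds shown here, two sharing one core have been measured in a functional assay on MV4-11 cells (Homo sapiens) for inhibition, read by resazurin assay, with a stated time of 72 h; a lower number here means a stronger inhibitor of growth, a higher number a weaker inhibitor of growth. Compound 1 `O=C1NCCC12CCN(c1c(Cl)cncc1-c1ccoc1)CC2`, which carries furan-3-yl, gives 750 nM. Compound 2 `O=Cc1sccc1-c1cncc(Cl)c1N1CCC2(CCNC2=O)CC1`, which carries 2-formylthiophen-3-yl instead, gives 28700 nM, the higher of the two numbers and so the weaker inhibitor of growth. Within the data shown here, the only measured step, a 38-fold higher number from compound 1 to compound 2 (1.58 log units; beyond the scatter), is large and beyond the scatter.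

Compound 3 `O=C1NCCC12CCN(c1c(Cl)cncc1-c1cnn(C(F)F)c1)CC2` has yet to be measured in this assay. Its change from compound 2 is this: 1-(difluoromethyl)-1H-pyrazol-4-yl in place of 2-formylthiophen-3-yl on an aromatic carbon. The new group, 1-(difluoromethyl)-1H-pyrazol-4-yl, stands on an aromatic carbon, ortho to a large group and meta to a chloro group. Among the measured compounds shown here, only that one measured step bears on the change, and no pyrazole has been measured yet. Compound 3 has no formyl group, so the closest reference is compound 1 at 750 nM. A large move towards a lower number is therefore expected, and the estimated step is a 32-fold lower number from compound 2 to compound 3 (1.50 log units; beyond the scatter). For compound 3 the estimated value is 900 nM, with an expected range from 250 nM to 4000 nM.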

Compound 3, concentration for 50% growth inhibition: 6140 nM
For compound 3 the middle estimate is 6.8-fold (0.83 log units) below the measured one; measured number above the stated range.
By their numbers in this assay, from the lowest: compound 1; then compound 3; then compound 2.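

In this assay, the step from 2-formylthiophen-3-yl to 1-(difluoromethyl)-1H-pyrazol-4-yl is a 4.7-fold lower number from compound 2 to compound 3 (0.67 log units; beyond the scatter), so a second kind of five-membered aromatic ring, this one with 2 hetero atoms, now places this position between the two earlier results. Set against furan-3-yl, the same pyrazole group gives an 8.2-fold higher number from compound 1 to compound 3 (0.91 log units; beyond the scatter), which shows that a group without a formyl group does not necessarily reach the level of compound 1, and compound 1 remains the strongest inhibitor of growth of the three. Nothing measured here accounts for the order of these three groups on the shared core.

The compounds shown leave open whether the gap between compound 1 and compound 3 follows the pyrazole ring itself or the difluoromethyl group on it, and a 1-methyl-1H-pyrazol-4-yl group or an unsubstituted 1H-pyrazol-4-yl group would bear directly on that question. They also leave the formyl group and the thiophene ring of compound 2 unseparated, and a plain thiophen-3-yl group would divide the two.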